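The source may hold more compounds than are shown below. What is called first, only, known or untested is meant among the compounds shown, and "the series" means these compounds.

Measured in a functional assay on DU-145 cells (Homo sapiens) for inhibition, read by trypan blue exclusion, with a stated time of 72 h; a lower number here means a stronger inhibitor, a higher number a weaker inhibitor:
- compound 1 `Cn1c(=O)c(S(=O)(=O)c2ccccc2)cc2cnc(Nc3ccc4cc[nH]c4c3)nc21` gives 10000 nM
- compound 2 `Cc1ccc(S(=O)(=O)c2cc3cnc(Nc4ccc5cc[nH]c5c4)nc3n(C)c2=O)cc1` gives 15000 nM

With only these two numbers to compare, compound 2 and compound 1 sit within the scatter of each other, and both are weak inhibitors. Among the compounds with values here, the one measured step, a 1.5-fold higher number from compound 1 to compound 2 (0.18 log units; within the scatter), is methyl in place of hydrogen on an aromatic carbon.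

Compound 3 `Cc1ccc(S(=O)(=O)c2cc3cnc(Nc4cccc5cccnc45)nc3n(C)c2=O)cc1` differs from compound 2 at another place: quinolin-8-yl in place of 1H-indol-6-yl on a nitrogen on an aromatic ring. The amino-linked group itself changes, from 1H-indol-6-yl to quinolin-8-yl. Within the data shown here, no measured step touches this group, so the methyl step offers little guidance on size or direction. No step beyond the scatter is therefore expected in this assay, though with low confidence. The expected step is a 1.3-fold lower number from compound 2 to compound 3 (0.10 log units; within the scatter). For compound 3 the estimate is 12000 nM, with an expected range of 3000 nM to 50000 nM.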

Compound 3, half-maximal inhibitory concentration: 10000 nM
Compound 3: the middle estimate sits 1.2-fold (0.08 log units) above what was measured, within the range that was stated.
By their numbers in this assay, from the lowest: compounds 1, 3 and 2 (each within the scatter of the next).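

In this assay, replacing 1H-indol-6-yl with quinolin-8-yl on the amino link gives a 1.5-fold lower number from compound 2 to compound 3 (0.18 log units; within the scatter) despite a sizeable swap: a five-membered aromatic ring with a hydrogen-bond donor leaves, and a second six-membered aromatic ring with a hydrogen-bond acceptor enters. This pair therefore cannot be told apart, so neither the ring pattern nor the swap of donor for acceptor separates these two groups at this position, and compound 2 and compound 3 both remain weak inhibitors. No measurement shown offers a reason for this result.

Going by these compounds, it remains open whether any other group on this nitrogen would give a clearly stronger inhibitor, such as a phenyl ring carrying a piperazine or a carboxylic acid. The effect of the quinoline nitrogen alone also stays unknown, since a plain naphthyl group is not among the compounds shown.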